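From hydroxy to methoxy on compound 3

A few compounds are considered here, and "the series" means these few. Any claim that something is new, unique, unknown or untested is made for them only; others in the source may bear on it.

Compound 1 `O=C(CCc1nc2ccccc2c(=O)[nH]1)N/N=C/c1ccc(O)c(O)c1`, compound 2 `COc1cc(/C=N/NC(=O)CCc2nc3ccccc3c(=O)[nH]2)ccc1O` and compound 3 `O=C(CCc1nc2ccccc2c(=O)[nH]1)N/N=C/c1cc(O)c(O)c(O)c1` share one core and differ only in the aromatic ring at one end. In a physicochemical assay, read by spectrophotometry, with a stated time of 6 min (on this read-out higher numbers stand for weaker inhibition and lower numbers for stronger inhibition), compound 1 gives 40000000 nM, compound 2 gives 95000000 nM and compound 3 gives 35000000 nM. The low end of these numbers is shared: the data show a 1.1-fold lower number from compound 1 to compound 3 (0.06 log units; within the scatter), whereas they also show a 2.7-fold lower number from compound 2 to compound 3 (0.43 log units; beyond the scatter).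

Compound 4 `COc1cc(/C=N/NC(=O)CCc2nc3ccccc3c(=O)[nH]2)cc(O)c1O` differs from compound 3 by a single change, (methyl in place of hydrogen on an oxygen on an aromatic ring), which turns a hydroxy into a methoxy. The same kind of change, methyl in place of hydrogen on an oxygen on an aromatic ring, appears once among the measured compounds, as a 2.4-fold higher number from compound 1 to compound 2 (0.38 log units; beyond the scatter), a modest step. This lone precedent is thin support, so only a modest step in the same direction is expected in this assay. The expected step is a 2.1-fold higher number from compound 3 to compound 4 (0.33 log units; beyond the scatter). For compound 4 the estimated value is 75000000 nM, with an expected range from 38000000 nM to 150000000 nM.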

Compound 4, half-maximal inhibitory concentration: 40000000 nM
Compound 4: the middle estimate sits 1.9-fold (0.27 log units) above what was measured; measured number inside the range.
By their numbers in this assay, from the lowest: compounds 3, 1 and 4 (each within the scatter of the next); then compound 2.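

In this assay the methyl in place of hydrogen on an oxygen on an aromatic ring gives a 1.1-fold higher number from compound 3 to compound 4 (0.06 log units; within the scatter) and so stays within the scatter, whereas the only earlier case of this change, a 2.4-fold higher number from compound 1 to compound 2 (0.38 log units; beyond the scatter) lies beyond it, so the same change does not read alike on the two rings. The added hydroxy gives a 2.4-fold lower number from compound 2 to compound 4 (0.38 log units; beyond the scatter) while the added methoxy gives no change at the digits printed from compound 1 to compound 4 (within the scatter) and thus leaves the number within the scatter. No measurement at hand accounts for the difference between the two methyl steps.

Going by these compounds, it remains open whether an ethyl group or a longer chain on this oxygen would stay within the scatter as well. On these data alone, an amine or a carboxylic acid in place of this hydroxy also remains open.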